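Methyl and chain variation in a cytotoxicity series

The source may hold more compounds than are shown below. What is called first, only, known or untested is meant among the compounds shown, and "the series" means these compounds.

Measured so far:
compound 1, `Cc1nc2c(Br)c(Br)c(Br)c(Br)c2n1CCCCC#N`: 92%
compound 2, `N#CCCn1cnc2c(Br)c(Br)c(Br)c(Br)c21`: 80%

In a functional assay on CCRF-CEM cells (Homo sapiens) for cytotoxicity, read by MTT assay, with a stated time of 24 h, tested at 10 uM (on this read-out higher numbers stand for a weaker effect at the one concentration tested and lower numbers for a stronger effect), compound 2 gives 80%, the lowest of the two numbers. Compound 1 differs from compound 2 in several places. In this assay, going by the values given here, compound 1 gives 92%, a number lying beyond the scatter above that of compound 2; no single-change step links the two, so the pair shows only that its values sit apart.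

Compound 3, `Cc1nc2c(Br)c(Br)c(Br)c(Br)c2n1CCC#N`, is compound 2 with one change: methyl in place of hydrogen on an aromatic carbon. Among the compounds with values here, compound 1 also carries a methyl, but differs elsewhere as well, so no measured step isolates the methyl on its own.

For the step from compound 2 to compound 3 a small shift toward weaker effect is expected, a number 6 percentage points higher from compound 2 to compound 3 (within the scatter), probably close to the edge of the scatter. Compound 3 is therefore estimated at 86% in this assay, with a range from 74% to 97%.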

Compound 3, a percentage reported as activity, at one concentration (the size of the read-out at that concentration, not a potency): 84%
Beside the measured number, compound 3's estimate is 2 percentage points above it, and the stated range covers the measured number.
By their numbers in this assay, from the lowest: compounds 2, 3 and 1 (each within the scatter of the next, the first and the last beyond it).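

In this assay, methyl in place of hydrogen on an aromatic carbon, between two ring nitrogen atoms, gives a number 4 percentage points higher from compound 2 to compound 3 (within the scatter), so this position accepts the methyl with no shift that stands clear of the usual variation. With the methyl present on both compounds, cyano in place of 2-cyanoethyl on a saturated chain carbon gives a number 8 percentage points lower from compound 1 to compound 3 (within the scatter), again no separable change. Compounds 1 and 2 sit apart by their printed values, yet each of the two single changes that connect them through compound 3 stays within the scatter.

From the compounds shown here alone, whether an amine or a phenyl ring at this position, or a carboxylic acid in place of the nitrile at the chain end, would give a step beyond the scatter remains open. The data on hand offer no evidence that explains either step.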